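Chlorine Position Outweighs Amide Substituent in This Series

The source may report more compounds than this note shows. Statements on the series, on what has been measured and on what is new or still open speak of the compounds shown alone.

Compound 1 `CN1CCc2nc(C#Cc3cccc(Cl)c3)ccc2C1=O`: 250 nM in an assay on HEK293 cells for displacement of a labelled ligand from metabotropic glutamate receptor 5 (Homo sapiens), with a stated time of 2 h; on this read-out higher numbers stand for weaker inhibition and lower numbers for stronger inhibition
Compound 2 `CN1CCc2nc(C#Cc3ccc(Cl)cc3)ccc2C1=O`: 6150 nM
Compound 3 `CC(C)N1CCc2nc(C#Cc3cccc(Cl)c3)ccc2C1=O`: 100 nM

Compound 3 gives the lowest number of the three. Its difference from compound 1 is isopropyl in place of methyl on an amide-type nitrogen in a ring, and the step is a 2.5-fold lower number from compound 1 to compound 3 (0.40 log units; beyond the scatter). Moving the chlorine matters far more: the change 4-chlorophenyl in place of 3-chlorophenyl on a triple-bonded carbon gives a 25-fold higher number from compound 1 to compound 2 (1.39 log units; beyond the scatter).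

Compound 4 `CC(C)N1CCc2nc(C#Cc3ccc(Cl)cc3)ccc2C1=O` has not been measured. It carries the same change as compound 2, now on the core of compound 3: 4-chlorophenyl in place of 3-chlorophenyl on a triple-bonded carbon. The two cores differ only as described by isopropyl in place of methyl on an amide-type nitrogen in a ring. Because the earlier step was a 25-fold higher number from compound 1 to compound 2 (1.39 log units; beyond the scatter), a step of similar size is expected here; the expected step is a 25-fold higher number from compound 3 to compound 4 (1.40 log units; beyond the scatter). For compound 4 the estimated value is 2500 nM, plausibly between 800 nM and 8000 nM.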

Compound 4, inhibition constant: 27100 nM
Beside the measured number, compound 4's estimate is 11-fold (1.04 log units) below it, and the stated range ends below it.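

In this assay the change to 4-chlorophenyl gives a 270-fold higher number from compound 3 to compound 4 (2.43 log units; beyond the scatter) and so keeps its direction on the second core but not its size: the same change on two cores in this assay, a 25-fold higher number (1.39 log units; beyond the scatter) from compound 1 to compound 2 and a 270-fold higher number (2.43 log units; beyond the scatter) from compound 3 to compound 4, 11-fold (1.04 log units) apart, beyond the scatter of two such steps. The change to isopropyl gives a 4.4-fold higher number from compound 2 to compound 4 (0.64 log units; beyond the scatter) on the 4-chlorophenyl compounds, the opposite direction to its step on the 3-chlorophenyl compounds: the same change on two cores in this assay, a 2.5-fold lower number (0.40 log units; beyond the scatter) from compound 1 to compound 3 and a 4.4-fold higher number (0.64 log units; beyond the scatter) from compound 2 to compound 4, 11-fold (1.04 log units) apart, beyond the scatter of two such steps. These four compounds show that the two changes do not simply add up here, so the size of a step on one core was a poor guide to its size on the other, but they do not show why, or how any further core would behave.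

On these data alone, whether this holds for a longer chain on the amide-type nitrogen stays open. So does the outcome with a methoxy group or a fluorine in place of the chlorine.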